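Exchanging the amide substituent in a kinase inhibitor series

The source may hold more compounds than are shown below. What is called first, only, known or untested is meant among the compounds shown, and "the series" means these compounds.

Compound 3 `CC(=O)N1CCCC(NC(=O)c2ccncc2Nc2cc(-c3ccc4ccn(C)c4c3)c3nccnc3c2)C1` gives 11 nM in an assay for inhibition of 6-phosphofructo-2-kinase/fructose-2,6-bisphosphatase 3 (Homo sapiens), read by ADP-Glo, with a stated time of 2 h; a higher number here means a weaker inhibitor, a lower number a stronger inhibitor. Compound 1 `CN1CCC(CNS(=O)(=O)c2ccccc2Nc2cc(-c3ccc4ccn(C)c4c3)c3nccnc3c2)C1` gives 11 nM in this assay, level with compound 3 at the digits shown, so the two stand together at the lowest of the three numbers. Compound 2 `CNC(=O)c1ccncc1Nc1cc(-c2ccc3ccn(C)c3c2)c2nccnc2c1` gives 83 nM in this assay, and the step of a 7.5-fold lower number from compound 2 to compound 3 (0.88 log units; beyond the scatter) shows how far apart they lie. Compound 4 `CN1CCC(CNC(=O)c2ccncc2Nc2cc(-c3ccc4ccn(C)c4c3)c3nccnc3c2)C1` is not yet measured; it differs from compound 3 by (1-methylpyrrolidin-3-yl)methyl in place of 1-acetylpiperidin-3-yl on an amide-type nitrogen. Within the data shown here, the one step that bears on this, a 7.5-fold lower number from compound 2 to compound 3 (0.88 log units; beyond the scatter), replaced methyl by a ring-bearing group, and compound 4 keeps a ring-bearing group; moreover compound 1 carries the same (1-methylpyrrolidin-3-yl)methyl group on a sulfonamide nitrogen with 11 nM. Compound 4 is therefore expected to show no change beyond the scatter, a 1.1-fold higher number from compound 3 to compound 4 (0.04 log units; within the scatter). The estimate for compound 4 is 12 nM, between 5 nM and 35 nM.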

Compound 4, half-maximal inhibitory concentration: 74 nM
Estimate against measurement, compound 4: 6.2-fold (0.79 log units) below; measured number above the stated range.
By their numbers in this assay, from the lowest: compounds 1 and 3 (each within the scatter of the next); then compounds 4 and 2 (each within the scatter of the next).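

At this amide-type nitrogen a ring-bearing group does not by itself lower the number in this assay: the exchange of 1-acetylpiperidin-3-yl for (1-methylpyrrolidin-3-yl)methyl gives a 6.7-fold higher number from compound 3 to compound 4 (0.83 log units; beyond the scatter). Against the methyl amide, the same group gives a 1.1-fold lower number from compound 2 to compound 4 (0.05 log units; within the scatter), so among these amides only 1-acetylpiperidin-3-yl stands apart. The compounds shown leave open whether that low number depends on the acetyl group or on the six-membered ring, which 1-methylpiperidin-3-yl or 1-acetylpyrrolidin-3-yl on this nitrogen could separate. No measurement given here accounts for the difference.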